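A few compounds are considered here, and "the series" means these few. Any claim that something is new, unique, unknown or untested is made for them only; others in the source may bear on it.

Compound 1 `CN1CCC[C@H]1COc1cncc(-c2ccccc2)c1`: 0.11 nM
Compound 2 `CN1CCC[C@H]1COc1cncc(-c2ccccc2C=O)c1`: 0.56 nM
Compound 3 `CN1CCC[C@H]1COc1cncc(-c2cccc([N+](=O)[O-])c2)c1`: 0.465 nM

All three were tested in an assay on membranes from brain for binding affinity to Neuronal acetylcholine receptor; alpha4/beta2 (Rattus norvegicus); a lower number here means a stronger inhibitor, a higher number a weaker inhibitor. Compound 1 gives the lowest number of the three. Its nearest neighbour is compound 3 at 0.465 nM, and the furthest is compound 2 at 0.56 nM; both gaps lie beyond the scatter.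

The next compound, compound 4 `COc1ccc(-c2cncc(OC[C@@H]3CCCN3C)c2)cc1`, differs from compound 1 in one place: methoxy in place of hydrogen on an aromatic carbon. Two measured steps resemble this change, since each also puts a group onto the six-membered aromatic ring of carbon only in compound 1: a 5.1-fold higher number from compound 1 to compound 2 (0.71 log units; beyond the scatter) and a 4.2-fold higher number from compound 1 to compound 3 (0.63 log units; beyond the scatter). Both are modest losses. A methoxy is a different group from a formyl or a nitro, and it sits para to a large group, so the two steps are only a rough guide, but they point the same way.

A modest loss is therefore expected for compound 4, about a 3.2-fold higher number from compound 1 to compound 4 (0.50 log units; beyond the scatter). Compound 4 is estimated at 0.35 nM, with a likely range from 0.1 nM to 1.2 nM.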

Compound 4, inhibition constant: 0.32 nM
Estimate against measurement, compound 4: 1.1-fold (0.04 log units) above; low and high end bracket the measured number.
By their numbers in this assay, from the lowest: compound 1; then compounds 4, 3 and 2 (each within the scatter of the next).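

Methoxy, para to a large group, also costs some binding, with a 2.9-fold higher number from compound 1 to compound 4 (0.46 log units; beyond the scatter) in this assay. A modest loss is therefore now seen at this place on the ring as well, and with a group other than formyl or nitro. All three groups shown on this ring give a higher number than the hydrogen of compound 1, and no compound here goes against that pattern.

Nothing given here accounts for the loss from methoxy. On these data alone, it also remains open whether a fluorine atom, a hydroxyl, an amine or a longer chain such as ethoxy at the same place would stay as close to compound 1, or would move further from it.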